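Moving the fluorine around the ring of compound 3

The source may hold more compounds than are shown below. What is called first, only, known or untested is meant among the compounds shown, and "the series" means these compounds.

Measured so far in a functional assay (muscle tissue) with Cavia porcellus as the target; on this read-out higher numbers stand for an effect only at larger amounts of compound and lower numbers for an effect already at smaller amounts:
compound 1 `COC(=O)C1=C(C)N=C(C)/C(=C(\O)OC)C1c1cccc(OC(C)=O)c1` gives 6030 nM;
compound 2 `C=Cc1ccccc1C1C(C(=O)OC)=C(C)N=C(C)/C1=C(\O)OC` gives 4.47 nM;
compound 3 `COC(=O)C1=C(C)N=C(C)/C(=C(\O)OC)C1c1ccccc1F` gives 42.7 nM.

Compound 3 stands second highest of these three numbers; its nearest neighbour is compound 2, and the step of a 9.6-fold higher number from compound 2 to compound 3 (0.98 log units; beyond the scatter) lies beyond the scatter, while compound 1 sits far above it. Compound 4 `COC(=O)C1=C(C)N=C(C)/C(=C(\O)OC)C1c1cccc(F)c1` differs from compound 3 only in the ring it carries: 3-fluorophenyl in place of 2-fluorophenyl on a saturated ring carbon. Among the measured compounds shown here, no measured step moves a fluorine from one ring position to another, so the data give no direct guide. The lone step in this assay exchanges groups rather than positions. Compound 4 is therefore expected to stay near compound 3, with a step of a 1.1-fold lower number from compound 3 to compound 4 (0.03 log units; within the scatter) that is not expected to exceed the scatter, giving an estimate of 40 nM with a range of 8 nM to 200 nM.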

Compound 4, half-maximal effective concentration: 20.9 nM
Compound 4: the middle estimate sits 1.9-fold (0.28 log units) above what was measured, and the stated range covers the measured number.
By their numbers in this assay, from the lowest: compound 2; then compound 4; then compound 3; then compound 1.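

In this assay, the place of the fluorine on the phenyl ring shifts the number: 3-fluorophenyl in place of 2-fluorophenyl gives a 2.0-fold lower number from compound 3 to compound 4 (0.31 log units; beyond the scatter) as a modest step, the first here that changes a position rather than a group. Compound 4 still lies short of compound 2, with a 4.7-fold higher number from compound 2 to compound 4 (0.67 log units; beyond the scatter) for that exchange, while fluoro in place of acetoxy gives a 290-fold lower number from compound 1 to compound 4 (2.46 log units; beyond the scatter) as a large step. Nothing available accounts for these differences.

From the compounds shown here alone, whether a nitrile or a trifluoromethyl group in place of the fluorine of compound 4 would give a lower or higher number remains open.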